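The compounds below may be only part of what the source reports. "The series", "measured", "known", "first", "only" and "open" are said of these compounds alone.

Measured so far in a functional assay on MRC5 cells (Homo sapiens); a lower number here means that less compound is tolerated, a higher number that more compound is tolerated:
- compound 1, `O=C1c2ccccc2N(Cc2ccc(C(F)(F)F)cc2)S(=O)(=O)N1Cc1ccccc1`: 56000 nM
- compound 2, `O=C1c2ccccc2N(CC2CCCCC2)S(=O)(=O)N1Cc1ccccc1`: > 65000 nM

Compound 2 reaches only the limit of this assay, (the limit of > 65000 nM in this assay, at which 1 of the 2 values shown sits), so its value is a bound and not a number. Against compound 1, which gives a real value, the step of an at least 1.1-fold higher number from compound 1 to compound 2 (0.06 log units; that floor lies within the scatter) is recorded; its floor sits within the scatter, so the two compounds cannot be separated on the numbers shown.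

Compound 3, `C#CCCN1c2ccccc2C(=O)N(Cc2ccccc2)S1(=O)=O`, differs from compound 2 by propargyl in place of cyclohexyl on a saturated chain carbon bound to a sulfonamide nitrogen in a ring; cut one bond further out, cyclohexylmethyl becomes but-3-yn-1-yl. For the measured compounds named here, the only step measured at this place is the one from compound 1 to compound 2, which did not move the number beyond the scatter. Going by the values given here, no step therefore argues for a change in this assay larger than the scatter, and for compound 3 a step of about an at least 1.1-fold lower number from compound 2 to compound 3 (0.07 log units; that floor lies within the scatter) is expected. Compound 3 is estimated at 55000 nM in this assay, in the range 25000 nM to 130000 nM, with a fair chance that only a limit is reported again.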

Compound 3, half-maximal cytotoxic concentration: 77000 nM
For compound 3 the middle estimate is 1.4-fold (0.15 log units) below the measured one; the measured number falls inside the stated range.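

In this assay, but-3-yn-1-yl at this position gives a 1.4-fold higher number from compound 1 to compound 3 (0.14 log units; within the scatter), so a ring on the saturated chain carbon bound to the sulfonamide nitrogen is not needed to stay in this range of tolerated concentrations. Neither the aromatic ring with its trifluoromethyl group nor the cyclohexyl ring has yet been tied to a change beyond the scatter. Compound 2 remains a limit, so the step to compound 3 cannot be read: the limit of > 65000 nM in this assay, at which 1 of the 3 values shown sits.

Going by these compounds, whether any group at this position can shift the number beyond the scatter remains open, for example a primary amine or a carboxylic acid at the end of the chain. On these data alone, the effect of changes elsewhere on the shared core is also open.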